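A few compounds are considered here, and "the series" means these few. Any claim that something is new, unique, unknown or untested is made for them only; others in the source may bear on it.

Values in a functional assay, with a stated time of 30 min; on this read-out lower numbers stand for stronger inhibition and higher numbers for weaker inhibition:
- Compound 1 `CCCCCCCCOc1cc(OC)c(Br)cc1C(C)=O` gives 39000000 nM
- Compound 2 `CCCCCCCCCCOc1cc(OC)c(Br)cc1C(C)=O` gives 35100000 nM
- Compound 3 `CCCCCCCCCCCCCCOc1cc(OC)c(Br)cc1C(C)=O` has not yet been measured

Compound 2, at 35100000 nM, stands within the scatter of compound 1, so the two numbers cannot be ranked. Compound 3 differs from compound 2 by butyl in place of hydrogen on a saturated chain carbon, ten or more bonds along the chain from an oxygen on an aromatic ring, which extends the same chain further. Among the measured compounds shown here, only one measured step bears on this change: a 1.1-fold lower number from compound 1 to compound 2 (0.05 log units; within the scatter), also made on the chain and no larger than the scatter. For the measured compounds named here, with only that step to go on, no clear shift is expected in this assay, although the added butyl is a larger change than the ethyl of that step. The expected result is a 1.2-fold lower number from compound 2 to compound 3 (0.07 log units; within the scatter), which would not be a change beyond the scatter. For compound 3 the estimated value is 30000000 nM, with an expected range from 13000000 nM to 60000000 nM.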

Compound 3, half-maximal inhibitory concentration: 16100000 nM
The estimate for compound 3 lay 1.9-fold (0.27 log units) above the measured number; the range from low to high includes it.
By their numbers in this assay, from the lowest: compound 3; then compounds 2 and 1 (each within the scatter of the next).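

In this assay this position on the saturated chain now gives a step beyond the scatter: butyl in place of hydrogen gives a 2.2-fold lower number from compound 2 to compound 3 (0.34 log units; beyond the scatter) and so does what the earlier ethyl step did not. Hexyl in place of hydrogen gives a 2.4-fold lower number from compound 1 to compound 3 (0.38 log units; beyond the scatter) and confirms that compound 3 stands apart from both shorter compounds, though both steps are modest. Nothing available accounts for this shift, which is seen only with the longest chain shown.

From the compounds shown here alone, whether a still longer chain would lower the number further, or whether the shift stops at compound 3, stays open. Also open, going by these compounds, is how the same place would read with a chain ending in a carboxylic acid or an amine.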